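Adding one chain carbon to compound 3

The source may report more compounds than this note shows. Statements on the series, on what has been measured and on what is new or still open speak of the compounds shown alone.

Values in an ADME assay on L6 cells (Rattus norvegicus) for cytotoxicity; on this read-out lower numbers stand for stronger inhibition and higher numbers for weaker inhibition:
- Compound 1 `CCN(CC)CC(=O)OC1CC2(N3CCCCC3)CC(c3ccccc3)C1C(c1ccccc1)C2`: 23900 nM; 61300 nM (2 entries)
- Compound 2 `CCN(CC)CCC(=O)OC1CC2(N3CCCCC3)CC(c3ccccc3)C1C(c1ccccc1)C2`: 22900 nM
- Compound 3 `O=C(CN1CCC(O)CC1)OC1CC2(N3CCCCC3)CC(c3ccccc3)C1C(c1ccccc1)C2`: > 179000 nM (a limit, not a number)

Compound 3 has no exact number, only the limit > 179000 nM. The change to compound 4 `O=C(CCN1CCC(O)CC1)OC1CC2(N3CCCCC3)CC(c3ccccc3)C1C(c1ccccc1)C2` puts (4-hydroxypiperidin-1-yl)methyl in place of 4-hydroxypiperidin-1-yl on a saturated chain carbon bound to a carbonyl carbon.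

Among the compounds with values here, the one measured step bearing on this is an at least 7.8-fold higher number from compound 2 to compound 3 (0.89 log units; beyond the scatter). It brought in 4-hydroxypiperidin-1-yl in place of (diethylamino)methyl, and its size lies beyond the scatter. Higher numbers here mean weaker inhibition, so the group entering compound 3 came with a clear move towards the weak end. Compound 2 gives 22900 nM and compound 1 gives 23900 nM; 61300 nM (2 entries), and these values lie in the same general region.

Within the data shown here, no measured step isolates the added chain carbon, so only a small move in this assay is expected, with the number staying high. Compound 4 is expected at about 120000 nM, with an estimated range of 45000 nM to 210000 nM. This estimate means an expected at least 1.4-fold lower number from compound 3 to compound 4 (0.17 log units; that floor lies within the scatter).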

Compound 4, half-maximal inhibitory concentration: 28500 nM
The estimate for compound 4 lay 4.2-fold (0.62 log units) above the measured number, and the stated range ends above it.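

In this assay, the step to (4-hydroxypiperidin-1-yl)methyl on a saturated chain carbon bound to a carbonyl carbon gives an at least 6.2-fold lower number from compound 3 to compound 4 (0.79 log units; beyond the scatter), so a single added chain carbon can matter a great deal here. Compound 3 has only a limit, which makes the size of that step a floor: the limit of > 179000 nM in this assay, at which 1 of the 4 values shown sits. With the longer chain, the choice of amine makes no clear difference, as the swap from diethylamino to 4-hydroxypiperidin-1-yl gives a 1.2-fold higher number from compound 2 to compound 4 (0.10 log units; within the scatter).

As far as these compounds go, the true size of the step remains open, since it depends on an exact number for compound 3. The compounds shown also leave open whether a still longer chain, such as 3-(4-hydroxypiperidin-1-yl)propyl, would stay in the same region or move the number again.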